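A few compounds are considered here, and "the series" means these few. Any claim that something is new, unique, unknown or untested is made for them only; others in the source may bear on it.

Measured compounds:
compound 1 `O=C1CS/C(=N\c2csc(-c3ccc(Cl)cc3)c2)N1`, 17100 nM in a functional assay on HT-29 cells (Homo sapiens) for cytotoxicity, read by MTT assay, with a stated time of 72 h; on this read-out higher numbers stand for weaker inhibition and lower numbers for stronger inhibition
compound 2 `COc1ccc(/C=C2\S/C(=N\c3csc(-c4ccc(Cl)cc4)c3)NC2=O)cc1`, 3800 nM
compound 3 `O=C1N/C(=N/c2csc(-c3ccc(Cl)cc3)c2)S/C1=C\c1ccc(Br)cc1`, 2000 nM

Compound 3 gives the lowest number of the three, though compound 2 sits within the scatter of it, and only compound 1, lacking the arylidene, gives a clearly higher number. Compound 4 `O=C1N/C(=N/c2csc(-c3ccc(Cl)cc3)c2)S/C1=C\c1ccccn1` differs from compound 3 by pyridin-2-yl in place of 4-bromophenyl on a double-bonded chain carbon bound to a double-bonded ring carbon. Among the measured compounds shown here, the one step that bears on this, a 1.9-fold lower number from compound 2 to compound 3 (0.28 log units; within the scatter), shows that exchanging the substituent on that ring changed little; there is no measured step in which the ring itself is replaced. A change of about the same modest size is therefore expected, a 1.8-fold higher number from compound 3 to compound 4 (0.24 log units; within the scatter), with no clear direction. Compound 4 is expected to give 3500 nM, between 1200 nM and 10000 nM.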

Compound 4, half-maximal inhibitory concentration: 11500 nM
For compound 4 the middle estimate is 3.3-fold (0.52 log units) below the measured one; the whole stated range lies below it.
By their numbers in this assay, from the lowest: compounds 3 and 2 (each within the scatter of the next); then compounds 4 and 1 (each within the scatter of the next).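

In this assay, the aromatic ring on this chain carbon proves able to shift the number beyond the scatter: pyridin-2-yl in place of 4-bromophenyl gives a 5.8-fold higher number from compound 3 to compound 4 (0.76 log units; beyond the scatter), and pyridin-2-yl in place of 4-methoxyphenyl gives a 3.0-fold higher number from compound 2 to compound 4 (0.48 log units; beyond the scatter). The earlier step changed only the substituent on the phenyl ring and stayed within the scatter, so it did not reveal this. No measurement at hand accounts for the difference. The compounds shown leave open how an amine or a carboxylic acid on the phenyl ring would read here. They also leave open whether a bromo or methoxy group on the pyridin-2-yl ring would change the number.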